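From pyrrolidin-1-yl to 4-hydroxypiperidin-1-yl on the shared core

The source may report more compounds than this note shows. Statements on the series, on what has been measured and on what is new or still open speak of the compounds shown alone.

Among the measured compounds shown here, in a functional assay on HCT-116 cells (Homo sapiens) for cytotoxicity, read by MTT assay, with a stated time of 72 h (on this read-out lower numbers stand for stronger inhibition and higher numbers for weaker inhibition), compound 1 (`O=S(=O)(c1ccccc1)c1nc2ccccc2nc1N1CCCC1`) gives 24200 nM and compound 2 (`O=S(=O)(c1ccc(F)cc1)c1nc2ccccc2nc1N1CCCC1`) gives 20600 nM, so compound 1 stands level with the only other measured compound. For the measured compounds named here, the single measured step, a 1.2-fold lower number from compound 1 to compound 2 (0.07 log units; within the scatter), is fluoro in place of hydrogen on an aromatic carbon, a different change, and offers only a weak guide. Compound 3 (`O=S(=O)(c1ccccc1)c1nc2ccccc2nc1N1CCC(O)CC1`) carries 4-hydroxypiperidin-1-yl in place of pyrrolidin-1-yl on an aromatic carbon. Going by the values given here, no measured step covers this exchange, so only a small move towards a higher number is expected, an estimated 1.2-fold higher number from compound 1 to compound 3 (0.09 log units; within the scatter). Compound 3 is estimated at 30000 nM, with an expected range of 12000 nM to 80000 nM.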

Compound 3, half-maximal inhibitory concentration: 1870 nM
The estimate for compound 3 lay 16-fold (1.21 log units) above the measured number; the whole stated range lies above it.
By their numbers in this assay, from the lowest: compound 3; then compounds 2 and 1 (each within the scatter of the next).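

In this assay, 4-hydroxypiperidin-1-yl in place of pyrrolidin-1-yl on an aromatic carbon gives a 13-fold lower number from compound 1 to compound 3 (1.11 log units; beyond the scatter). This place, next to the ring nitrogen, is thus the first in the series where a single change moves the number beyond the scatter, unlike the fluoro exchange on the other aryl group. Nothing available bears on the reason for the size of this step.

The compounds shown leave open whether the six-membered ring or the hydroxy group carries the step; piperidin-1-yl would separate the two. Also open, on these data alone, is how 4-aminopiperidin-1-yl would compare in the same place.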